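The compounds below may be only part of what the source reports. "The series", "measured", "known", "first", "only" and "open" are said of these compounds alone.

Of the compounds shown here, three sharing one core have been measured in an assay on LtK cells with ATP-sensitive inward rectifier potassium channel 11 (Homo sapiens) as the target; a higher number here means that more compound is needed for the effect, a lower number that less compound is needed. Compound 1 `CC(C)OC(=O)Nc1c(C(O)(C(F)(F)F)C(F)(F)F)ccc2ccccc12` gives 1160 nM. Compound 2 `Cc1cccc(C(=O)Nc2c(C(O)(C(F)(F)F)C(F)(F)F)ccc3ccccc23)c1` gives 23 nM, and compound 3 `Cc1ccc(C(=O)Nc2c(C(O)(C(F)(F)F)C(F)(F)F)ccc3ccccc23)cc1` gives 76 nM. The step of a 50-fold lower number from compound 1 to compound 2 (1.70 log units; beyond the scatter) and the step of a 15-fold lower number from compound 1 to compound 3 (1.18 log units; beyond the scatter) were both large, while the step of a 3.3-fold higher number from compound 2 to compound 3 (0.52 log units; beyond the scatter) was modest. Compound 3 thus stands second of the three numbers, closer to compound 2 than to compound 1.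

Compound 4 `O=C(Nc1c(C(O)(C(F)(F)F)C(F)(F)F)ccc2ccccc12)c1ccc(C(F)(F)F)cc1` differs from compound 3 by trifluoromethyl in place of methyl on an aromatic carbon. Among the compounds with values here, no measured step replaces a methyl with a trifluoromethyl. The large steps from compound 1 concern the whole aryl amide entering in place of the carbamate, and that amide remains in compound 4. Within the data shown here, the one step among the aryl amides is modest, and because a 3.3-fold higher number from compound 2 to compound 3 (0.52 log units; beyond the scatter) was the only guide, a change within the scatter or a modest one in either direction is expected, namely the estimated step of a 1.1-fold lower number from compound 3 to compound 4 (0.04 log units; within the scatter). Compound 4 is therefore expected at 70 nM in this assay, between 20 nM and 250 nM.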

Compound 4, half-maximal effective concentration: 160 nM
The estimate for compound 4 lay 2.3-fold (0.36 log units) below the measured number; the range from low to high includes it.
By their numbers in this assay, from the lowest: compound 2; then compound 3; then compound 4; then compound 1.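

In this assay trifluoromethyl in place of methyl on this aromatic carbon, para to a large group, gives a 2.1-fold higher number from compound 3 to compound 4 (0.32 log units; beyond the scatter) and so shows that this position responds to the change, though only modestly. The aryl amide still keeps a clear advantage over the carbamate with a 7.3-fold lower number from compound 1 to compound 4 (0.86 log units; beyond the scatter) as the measured step, while a 7.0-fold higher number from compound 2 to compound 4 (0.84 log units; beyond the scatter) leaves the 3-methylphenyl amide with the lowest number of the four. Nothing available explains why the number rises with trifluoromethyl here.

On these data alone, what a chlorine, a methoxy group or an amine would do on this same carbon remains open, so two groups cannot define a trend at this position. As far as these compounds go, it is also open whether trifluoromethyl in place of the methyl of compound 2 would move the number in the same direction.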